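A few compounds are considered here, and "the series" means these few. Any claim that something is new, unique, unknown or untested is made for them only; others in the source may bear on it.

Measured so far in a functional assay on WiDr cells (Homo sapiens) for cytotoxicity, read by MTT assay, with a stated time of 48 h; a lower number here means a stronger inhibitor, a higher number a weaker inhibitor:
Compound 1 `COC(=O)c1cc2n(c1C)[C@@H](c1ccccc1)SC2`: 57100 nM
Compound 2 `Cc1c(CO)cc2n1[C@@H](c1ccccc1)SC2`: 17100 nM

Among the compounds with values here, compound 2 stands at the lower of the two numbers in this assay; the only measured step, a 3.3-fold lower number from compound 1 to compound 2 (0.52 log units; beyond the scatter), is a modest drop. Compound 3 `Cc1c(CO)c(CO)c2n1[C@@H](c1ccccc1)SC2` differs from compound 2 by hydroxymethyl in place of hydrogen on an aromatic carbon. Within the data shown here, no measured step puts a hydroxymethyl where hydrogen stood; the one available comparison swaps methoxycarbonyl for hydroxymethyl and lowers the number modestly, so at most a small further lowering in this assay is expected, within or just beyond the scatter. The step is estimated as a 1.4-fold lower number from compound 2 to compound 3 (0.15 log units; within the scatter). Compound 3 is expected near 12000 nM, between 4000 nM and 40000 nM.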

Compound 3, half-maximal inhibitory concentration: 9100 nM
The estimate for compound 3 lay 1.3-fold (0.12 log units) above the measured number; low and high end bracket the measured number.
By their numbers in this assay, from the lowest: compounds 3 and 2 (each within the scatter of the next); then compound 1.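

In this assay, hydroxymethyl in place of hydrogen on an aromatic carbon, next to the ring atom that bears a fused ring, gives a 1.9-fold lower number from compound 2 to compound 3 (0.27 log units; within the scatter). This position therefore takes a second hydroxymethyl with no change beyond the scatter, and compound 2 and compound 3 read as one level. No evidence on the basis of this result is available. Open, from the compounds shown here alone, is whether an amine, a carboxylic acid or a longer chain at this position would shift the number beyond the scatter. Also open, going by these compounds, is how methoxycarbonyl would read here.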